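The source may hold more compounds than are shown below. What is called first, only, known or untested is meant among the compounds shown, and "the series" means these compounds.

Compound 1 `COc1ccc(C(=O)/C=C/c2cccc(F)c2)c2c1C=CC(C)(C)O2` in a functional assay on HT-29 cells (Homo sapiens) for antiproliferative activity, read by MTT assay, with a stated time of 24 h (on this read-out higher numbers stand for weaker inhibition and lower numbers for stronger inhibition), gives only a limit of the assay, > 10000 nM. Compound 2 `COc1ccc(C(=O)/C=C/c2ccc(Br)cc2)c2c1C=CC(C)(C)O2` in this assay likewise gives only a limit, > 10000 nM. Compound 3 `CCN(CC)c1ccc(/C=C/C(=O)c2ccc(OC)c3c2OC(C)(C)C=C3)cc1` in this assay gives 550 nM.

Compound 3 therefore holds the only actual number shown; the two other values are limits. Compound 4 `COc1ccc(C(=O)/C=C/c2ccc([N+](=O)[O-])cc2)c2c1C=CC(C)(C)O2` differs from compound 3 by nitro in place of diethylamino on an aromatic carbon. The step that the two limits leave unreadable from compound 1 to compound 2 cannot be read since both values sit at the limit of > 10000 nM in this assay, at which 2 of the 3 values shown sit. The step that bears on the change is an at least 18-fold lower number from compound 2 to compound 3 (1.25 log units; beyond the scatter), where a substituent other than diethylamino left the value at the limit. A reversal of that step is the natural reading. The number for compound 4 is accordingly expected to move back upward, by a 15-fold higher number from compound 3 to compound 4 (1.16 log units; beyond the scatter). Compound 4 is estimated at 8000 nM, within a range of 2000 nM to 30000 nM.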

Compound 4, half-maximal inhibitory concentration: 3730 nM
Estimate against measurement, compound 4: 2.1-fold (0.33 log units) above; measured number inside the range.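

On this aromatic carbon, para to a large group, diethylamino is not the only substituent that lifts the value off the limit: nitro does so too, with an at least 2.6-fold lower number from compound 2 to compound 4 (0.42 log units; beyond the scatter) and an at least 2.6-fold lower number from compound 1 to compound 4 (0.42 log units; beyond the scatter). Both steps are only bounds, and the step between compound 1 and compound 2 cannot be read, because each of those two compounds gives only a limit: the limit of > 10000 nM in this assay, at which 2 of the 4 values shown sit. Nitro still falls short of diethylamino in this assay, with a 6.8-fold higher number from compound 3 to compound 4 (0.83 log units; beyond the scatter). From the compounds shown here alone, it remains open whether dimethylamino, a primary amine or methoxy at this place would give a number nearer that of compound 3 or that of compound 4.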